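This account rests on a few compounds, and the source may have more. Where it says the series, first, only, none or still open, it means among the compounds named here.

Working notes on the series. a functional assay on MCF7 cells (Homo sapiens) for cytotoxicity, read by CellTiter-Glo, with a stated time of 5 days (a lower number here means a stronger inhibitor, a higher number a weaker inhibitor), is the single read-out available. The parent compound 1, `CC/C(=C(/c1ccc(/C=C/C(=O)O)cc1)c1ccc2[nH]ncc2c1)c1ccccc1`, gives 7.2 nM. Compound 2, `CCCC/C(=C(/c1ccc(/C=C/C(=O)O)cc1)c1ccc2[nH]ncc2c1)c1ccccc1`, gives 10 nM; the step of a 1.4-fold higher number from compound 1 to compound 2 (0.14 log units; within the scatter) is within the scatter. For the measured compounds named here, compound 3, `CC/C(=C(/c1ccc(/C=C/C(=O)O)cc1)c1ccc2[nH]ncc2n1)c1ccccc1`, gives 33 nM and carries the highest number of the three; the only step reaching it is a 4.6-fold higher number from compound 1 to compound 3 (0.66 log units; beyond the scatter), and its value also sits clearly above that of compound 2.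

Compound 4, `CC/C(=C(/c1ccc(/C=C/C(=O)O)cc1)c1cc2cn[nH]c2cn1)c1ccccc1`, is the next variant. The change from compound 3 is a group of 9 heavy atoms (6 carbon, 3 nitrogen; one five-membered aromatic ring with 2 hetero atoms, one six-membered aromatic ring with 1 hetero atom) in place of a group of 9 heavy atoms (6 carbon, 3 nitrogen; one five-membered aromatic ring with 2 hetero atoms, one six-membered aromatic ring with 1 hetero atom), on a double-bonded chain carbon bound to an aromatic carbon and a double-bonded chain carbon: the same atoms, joined differently, within the bicyclic group on the double-bonded chain carbon bound to an aromatic carbon and a double-bonded chain carbon.

Going by the values given here, no measured step rearranges atoms inside that bicyclic group. Among the compounds with values here, the one step bearing on the same position, a 4.6-fold higher number from compound 1 to compound 3 (0.66 log units; beyond the scatter), shows that swapping one nine-atom bicyclic group for another there moves this assay by a modest amount. An isomer swap is expected to move the number by no more than that, in an unknown direction, and the estimate is therefore kept close to compound 3 with a wide range. Compound 4 is estimated at 30 nM, between 8 nM and 110 nM, meaning an expected step of a 1.1-fold lower number from compound 3 to compound 4 (0.04 log units; within the scatter).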

Compound 4, half-maximal inhibitory concentration: 442 nM
Compound 4: middle estimate off by 15-fold (1.17 log units), on the low side; measured number above the stated range.
By their numbers in this assay, from the lowest: compounds 1 and 2 (each within the scatter of the next); then compound 3; then compound 4.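

In this assay, the arrangement of atoms within the bicyclic group on the double-bonded chain carbon bound to an aromatic carbon and a double-bonded chain carbon matters in its own right: the group keeps the same heavy atoms, ring types, hydrogen-bond donor and acceptor counts and net charge, yet a 13-fold higher number from compound 3 to compound 4 (1.13 log units; beyond the scatter) is a large step. That step is larger than the modest 4.6-fold higher number from compound 1 to compound 3 (0.66 log units; beyond the scatter), so the earlier exchange at this position did not show the full sensitivity of this assay to the group, and a 61-fold higher number from compound 1 to compound 4 (1.79 log units; beyond the scatter) places the two nitrogen-containing isomers at very different distances from the parent. No supporting measurement bears on the origin of this difference.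

Still open, going by these compounds, is whether a methyl or a fluorine carried on the bicyclic group of compound 4 would move the number, and in which direction. Also open, on these data alone, is whether the longer chain of compound 2, which sits within the scatter of compound 1, would leave the step to the group of compound 4 unchanged if the two changes were combined.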